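The source may report more compounds than this note shows. Statements on the series, on what has been measured and on what is new or still open speak of the compounds shown alone.

Measured compounds: compound 1 `O=C(CCCCCNc1c(Nc2ccccc2)c(=O)c1=O)NO` with < 4.8 uL/min in an ADME assay on cells (Hepatocyte, Homo sapiens) for pharmacokinetics, read by LC-MS, with a stated time of 90 min, tested at 1 uM; a higher number here means faster removal of the compound, a lower number slower removal; compound 2 `Cc1cccc(Nc2c(NCCCCCC(=O)NO)c(=O)c2=O)c1` with 18 uL/min in this assay.

In this assay compound 1 gives < 4.8 uL/min, which is a limit of the assay and not a number. Compound 1 therefore stands at the limit of < 4.8 uL/min in this assay, at which 1 of the 2 values shown sits, the slow end of what is shown. Compound 2 sits higher, the step being an at least 3.7-fold higher number from compound 1 to compound 2 (0.57 log units; beyond the scatter).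

Compound 3 `CC(CCCCC(=O)NO)Nc1c(Nc2ccccc2)c(=O)c1=O` has not yet been measured in this assay. It differs from compound 1 by methyl in place of hydrogen on a saturated chain carbon bound to a nitrogen on an aromatic ring and a saturated chain carbon. Among the compounds with values here, the one measured step, an at least 3.7-fold higher number from compound 1 to compound 2 (0.57 log units; beyond the scatter), also adds a methyl, but on an aromatic carbon rather than on the saturated chain, so it bears only loosely on this change. A small rise above the limit is expected for compound 3, with wide uncertainty, and the step of an at least 1.2-fold higher number from compound 1 to compound 3 (0.09 log units; that floor lies within the scatter) is the estimate. Compound 3 is expected to give about 6 uL/min, within 3 uL/min to 15 uL/min, in this assay.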

Compound 3, intrinsic clearance in a liver preparation (reported as CLH), per the amount of preparation that the assay uses: < 5 uL/min
Compound 3 was reported as a limit; the forecaster's own chance of this, stated with the estimate: 40%; middle value at least 1.2-fold (0.07 log units) away from the limit.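

In this assay compound 3 gives < 5 uL/min, a limit of the assay and not a number. Within the data shown here, compound 1 also stands at a limit, so no step between compound 1 and compound 3 can be read. The compounds shown leave open how far either value lies under its limit.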